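The source may hold more compounds than are shown below. What is called first, only, known or untested is meant among the compounds shown, and "the series" means these compounds.

Of the compounds shown here, three sharing one core have been measured in a physicochemical assay for solubility, read by LC-MS, in phosphate buffer, measured as thermodynamic solubility, with a stated time of 24 h, at pH 7.4; a higher number here means a more soluble compound, a lower number a less soluble compound. Compound 2 `Cn1cc(-c2cnc3[nH]cc(-c4ccccc4)c3c2)cn1` gives 20000 nM, the largest of the three numbers, although the step of a 1.8-fold higher number from compound 1 to compound 2 (0.26 log units; within the scatter) lies within the scatter, so compound 1 `Cn1cc(-c2cnc3[nH]cc(-c4ccccc4C#N)c3c2)cn1` with 11000 nM cannot be told apart from it. Compound 3 `Cn1cc(-c2cnc3[nH]cc(-c4ccc(C(N)=O)cc4)c3c2)cn1` gives 3000 nM, and the step of a 6.7-fold lower number from compound 2 to compound 3 (0.82 log units; beyond the scatter) is a real, if modest, drop.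

Compound 4 `Cn1cc(-c2cnc3[nH]cc(-c4ccncc4)c3c2)cn1` has not yet been measured. It differs from compound 2 in one place: pyridin-4-yl in place of phenyl on an aromatic carbon.

Neither measured step matches this change. The step from compound 1 to compound 2 and the step from compound 2 to compound 3 each swap a group on the outer ring for a hydrogen or back, while keeping that ring as phenyl; here the ring itself is exchanged, with its position on the core unchanged. Going by the values given here, with no example of a pyridin-4-yl in this set, the measured steps give no direct guide, and the expectation rests on the change being small in size. The expected step is a 1.5-fold higher number from compound 2 to compound 4 (0.18 log units; within the scatter), a rise that may not clear the scatter. Compound 4 is therefore estimated at 30000 nM, within a range from 10000 nM to 90000 nM.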

Compound 4, solubility: 59000 nM
Estimate against measurement, compound 4: 2.0-fold (0.29 log units) below; low and high end bracket the measured number.
By their numbers in this assay, from the lowest: compound 3; then compounds 1 and 2 (each within the scatter of the next); then compound 4.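

In this assay, exchanging the phenyl for pyridin-4-yl gives a 3.0-fold higher number from compound 2 to compound 4 (0.47 log units; beyond the scatter), a step that clears the scatter even though the entering ring has the same count of heavy atoms as the one it replaces, with one ring carbon exchanged for a nitrogen and one hydrogen-bond acceptor gained, and no net charge on either group. Going by these compounds alone, until now, the only step beyond the scatter on this outer ring was a fall, a 6.7-fold lower number from compound 2 to compound 3 (0.82 log units; beyond the scatter), so the result shows that the number at this place on the five-membered ring of the shared core can also move up, and that changing the ring itself can matter as much as adding a group to it. The data shown offer no measurement that explains the rise, so its cause remains unknown.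

On these data alone, it remains open whether the location of the ring nitrogen matters, which a pyridin-3-yl or pyridin-2-yl group at the same place would help to show. As far as these compounds go, it is also open whether a nitrile or carbamoyl group on pyridin-4-yl would shift the number as those groups do on phenyl, and whether a pyrimidinyl ring would carry the step further.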